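Replacing the Amide Side Chain by an Ester in a Spiro Series

This account rests on a few compounds, and the source may have more. Where it says the series, first, only, none or still open, it means among the compounds named here.

The measured compounds and their values:
compound 1 `CC(C)(C)OC(=O)NCCCCCNC(=O)CN1CN(c2ccccc2)C2(CCN(C(=O)c3ccc(C(C)(C)C)cc3)CC2)C1=O`, 13700 nM
compound 2 `CC(C)(C)c1ccc(C(=O)N2CCC3(CC2)C(=O)N(CC(=O)NCCN)CN3c2ccccc2)cc1`, 7000 nM
compound 3 `CC(C)(C)OC(=O)NCCCCNC(=O)CN1CN(c2ccccc2)C2(CCN(C(=O)c3ccc(C4CCCCC4)cc3)CC2)C1=O`, 4600 nM

All three were tested in an assay on HEK293 cells for displacement of a labelled ligand from NPC1-like intracellular cholesterol transporter 1 (Homo sapiens); on this read-out lower numbers stand for stronger inhibition and higher numbers for weaker inhibition. Compound 2 gives the second highest of the three numbers: compound 3 sits nearest to it and compound 1 furthest, and both gaps lie within the scatter, so no order among the three can be drawn.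

Compound 4 `CC1(C)CC(OC(=O)CN2CN(c3ccccc3)C3(CCN(C(=O)c4ccc(C(C)(C)C)cc4)CC3)C2=O)CC(C)(C)N1` has not yet been measured. It differs from compound 2 in one place: (2,2,6,6-tetramethylpiperidin-4-yl)oxy in place of (2-aminoethyl)amino on a carbonyl carbon.

Within the data shown here, only one measured step touches the same part of the molecule, the side chain on the carbonyl carbon. That step, a 2.0-fold lower number from compound 1 to compound 2 (0.29 log units; within the scatter), replaced 3-((tert-butoxycarbonyl)amino)propyl with amino and moved the number no further than the scatter. Among the measured compounds shown here, the change to compound 4 is larger in what leaves and what enters, but there is no measured step that shows such an exchange, so the direction cannot be read from the data. Compound 4 is therefore expected to stay close to compound 2, with the step of a 1.1-fold higher number from compound 2 to compound 4 (0.06 log units; within the scatter) estimated to remain within the scatter. The estimate for compound 4 in this assay is 8000 nM, with a range from 2500 nM to 25000 nM.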

Compound 4, half-maximal inhibitory concentration: 1300 nM
For compound 4 the middle estimate is 6.2-fold (0.79 log units) above the measured one, outside the stated range (below it).
By their numbers in this assay, from the lowest: compound 4; then compounds 3, 2 and 1 (each within the scatter of the next, the first and the last beyond it).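

In this assay, the exchange of (2-aminoethyl)amino for (2,2,6,6-tetramethylpiperidin-4-yl)oxy on the carbonyl carbon gives a 5.4-fold lower number from compound 2 to compound 4 (0.73 log units; beyond the scatter), whereas the earlier step in this side chain, a 2.0-fold lower number from compound 1 to compound 2 (0.29 log units; within the scatter), stayed within the scatter. The number therefore does respond to what is attached to this carbonyl carbon. No measurement shown accounts for the shift.

The change swaps the amide-type link for an ester and the open chain for a six-membered ring in a single step, and the compounds shown do not separate these two parts. A (2,2,6,6-tetramethylpiperidin-4-yl)amino group or a (2-aminoethyl)oxy group on the same carbonyl carbon would be needed to tell whether the ring or the ester oxygen goes with the lower number.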